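A hydroxy group on the chain of compound 1

This account rests on a few compounds, and the source may have more. Where it says the series, first, only, none or still open, it means among the compounds named here.

Measured compounds in a functional assay on NTUB1 cells (Homo sapiens) for cytotoxicity, read by MTT assay, with a stated time of 48 h; a lower number here means a stronger inhibitor, a higher number a weaker inhibitor 
compound 1 `C=C1CC[C@@H]2[C@](C)(CO)[C@H](O)CC[C@@]2(C)[C@@H]1CCc1ccoc1` gives 39800 nM 
compound 2 `C=C1CC[C@@H]2[C@](C)(COC(=O)c3ccc([N+](=O)[O-])cc3)[C@H](O)CC[C@@]2(C)[C@@H]1CCc1ccoc1` gives 23800 nM 
compound 3 `C=C1CC[C@@H]2[C@](C)(COC(=O)c3ccc(OC)cc3)[C@H](O)CC[C@@]2(C)[C@@H]1CCc1ccoc1` gives 26300 nM 

Compound 1 holds no distinct place among these three values. The steps away from it (a 1.7-fold lower number from compound 1 to compound 2 (0.22 log units; within the scatter); a 1.5-fold lower number from compound 1 to compound 3 (0.18 log units; within the scatter)) lie within the scatter, and so does the step between the other two (a 1.1-fold higher number from compound 2 to compound 3 (0.04 log units; within the scatter)).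

Compound 4 (`C=C1CC[C@@H]2[C@](C)(CO)[C@H](O)CC[C@@]2(C)[C@@H]1CC(O)c1ccoc1`) differs from compound 1 by a single change (hydroxy in place of hydrogen on a saturated chain carbon bound to an aromatic carbon and a saturated chain carbon): hydroxy in place of hydrogen on a saturated chain carbon bound to an aromatic carbon and a saturated chain carbon. Cut one bond further out, this reads 2-(furan-3-yl)ethyl to 2-(furan-3-yl)-2-hydroxyethyl.

Among the measured compounds shown here, no measured step touches that place. The steps at hand all concern an oxygen on a saturated carbon elsewhere in the molecule, so they bear on this change only indirectly. The replacements in compound 2 (a 1.7-fold lower number from compound 1 to compound 2 (0.22 log units; within the scatter)) and compound 3 (a 1.5-fold lower number from compound 1 to compound 3 (0.18 log units; within the scatter)) stayed within the scatter, so no step beyond it is expected here, and the data suggest no direction. The estimated step (a 1.1-fold lower number from compound 1 to compound 4 (0.06 log units; within the scatter)) is therefore expected to be slight. Compound 4 is expected at 35000 nM (estimated range from 15000 nM to 80000 nM).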

Compound 4, half-maximal inhibitory concentration: > 100000 nM
Compound 4: a limit, no number (the forecaster's own chance of this, stated with the estimate: 15%); middle value at least 2.8-fold (0.45 log units) from the limit.
By their numbers in this assay, from the lowest: compounds 2, 3 and 1 (each within the scatter of the next). At a limit, above all of these: compound 4.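

In this assay, compound 4 gives > 100000 nM, and this value is a limit of the assay, not a number. The change from 2-(furan-3-yl)ethyl to 2-(furan-3-yl)-2-hydroxyethyl gives an at least 2.5-fold higher number from compound 1 to compound 4 (0.40 log units; beyond the scatter), the only step shown that lies beyond the scatter, whereas both replacements on the oxygen on a saturated carbon stayed within it. The saturated chain carbon bound to an aromatic carbon and a saturated chain carbon is thus the one place in this small series where a change of a single hydroxy moves the result towards a weaker inhibitor, and the full size of that step is bounded from one side only: the limit of > 100000 nM in this assay, at which 1 of the 4 values shown sits.

As far as these compounds go, whether this shift belongs to the hydroxy itself or would also follow from another group on the same carbon remains open, and a methoxy, an acetate ester, an amine or a ketone carbonyl at that place would help to separate these readings. From the compounds shown here alone, it also remains open whether a 4-nitrobenzoyl or 4-methoxybenzoyl ester on the other oxygen would keep its place within the scatter when the chain carries this hydroxy.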